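A longer chain on compound 3

A few compounds are considered here, and "the series" means these few. Any claim that something is new, unique, unknown or untested is made for them only; others in the source may bear on it.

Measured so far in a functional assay on HT-29 cells (Homo sapiens) for inhibition, read by sulforhodamine B assay, with a stated time of 72 h (on this read-out higher numbers stand for weaker inhibition and lower numbers for stronger inhibition), are these compounds:
compound 1 `COc1cc2c(Nc3ccc(F)c(Cl)c3)ncnc2cc1OCCCCCCn1ccnc1[N+](=O)[O-]` with 1840 nM as its value
compound 2 `COc1cc2c(Nc3cccc(Br)c3)ncnc2cc1OCCCn1ccnc1[N+](=O)[O-]` with 2820 nM as its value
compound 3 `COc1cc2c(Nc3cccc(Br)c3)ncnc2cc1OCCCCn1ccnc1[N+](=O)[O-]` with 1430 nM as its value

On these numbers compound 3 cannot be separated from compound 1 or from compound 2, as both lie within the usual scatter of it.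

Compound 4 `COc1cc2c(Nc3cccc(Br)c3)ncnc2cc1OCCCCCCn1ccnc1[N+](=O)[O-]` has not yet been measured. It carries 2-(2-nitro-1H-imidazol-1-yl)ethyl in place of 2-nitro-1H-imidazol-1-yl on a saturated chain carbon, four bonds along the chain from an oxygen on an aromatic ring, and the change counts as 2-(2-nitro-1H-imidazol-1-yl)ethyl in place of 2-nitro-1H-imidazol-1-yl on a saturated chain carbon, four bonds along the chain from an oxygen on an aromatic ring in all.

For the measured compounds named here, one measured step bears directly on this kind of change. The chain extension a 2.0-fold lower number from compound 2 to compound 3 (0.29 log units; within the scatter) stayed within the scatter. Compound 1, at 1840 nM in the same read-out, also sits within the scatter of compound 3. Going by the values given here, nothing measured so far therefore points to a step beyond the scatter in this assay for this change, and no direction is favoured. The expected step, a 1.0-fold higher number from compound 3 to compound 4 (0.02 log units; within the scatter) as estimated here, is correspondingly small. For compound 4 the estimated value is 1500 nM with an expected range from 700 nM to 3200 nM in this read-out.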

Compound 4, half-maximal inhibitory concentration: 4300 nM
For compound 4 the middle estimate is 2.9-fold (0.46 log units) below the measured one, and the stated range ends below it.
By their numbers in this assay, from the lowest: compounds 3, 1, 2 and 4 (each within the scatter of the next, the first and the last beyond it).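

In this assay, for the compounds shown here, lengthening the chain at this position gives a 3.0-fold higher number from compound 3 to compound 4 (0.48 log units; beyond the scatter) and so provides the first chain step in the 3-bromophenyl compounds to pass beyond the scatter, showing that chain length can register in this assay. The effect is not a steady trend with length, however: a 1.5-fold higher number from compound 2 to compound 4 (0.18 log units; within the scatter) leaves the two chain ends of this group unresolved, and compound 2 goes against any simple rule that a longer chain gives a higher number. Going by these compounds alone, with the longer chain held constant, 3-bromophenyl in place of 3-chloro-4-fluorophenyl on a nitrogen on an aromatic ring gives a 2.3-fold higher number from compound 1 to compound 4 (0.37 log units; beyond the scatter) and shows for the first time that this aryl group also registers in the read-out.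

Nothing shown here gives a measured reason for either step. As far as these compounds go, it remains open whether a still longer chain would continue the rise in the number, whether the aryl step would recur on the shorter chains, and whether an amine in place of the 2-nitro-1H-imidazol-1-yl group would keep the same dependence on chain length.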